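The source may report more compounds than this note shows. Statements on the series, on what has been measured and on what is new or still open speak of the compounds shown alone.

Compound 3 `O=C(/C=C/c1ccc(O)cc1)c1c(O)cccc1OCC1CCCCC1` carries a cyclohexyl on a saturated chain carbon bound to an oxygen on an aromatic ring. In a functional assay on ACHN cells (Homo sapiens) for antiproliferative activity, read by sulforhodamine B assay (on this read-out lower numbers stand for stronger inhibition of growth and higher numbers for weaker inhibition of growth), compound 3 gives only a limit, > 30000 nM. Compound 2 `CC(C)=CCOc1cccc(O)c1C(=O)/C=C/c1ccc(O)cc1` likewise gives only a limit, > 30000 nM. Compound 1 `CC(C)CCCOc1cccc(O)c1C(=O)/C=C/c1ccc(O)cc1` gives 3630 nM, so the steps of an at least 8.2-fold higher number from compound 1 to compound 3 (0.91 log units; beyond the scatter) and an at least 8.2-fold higher number from compound 1 to compound 2 (0.91 log units; beyond the scatter) both run toward weaker growth inhibition, while the step that the two limits leave unreadable from compound 2 to compound 3 cannot be read. Compound 4 `O=C(/C=C/c1ccc(O)cc1)c1c(O)cccc1OCCC1CCCC1` differs from compound 3 by cyclopentylmethyl in place of cyclohexyl on a saturated chain carbon bound to an oxygen on an aromatic ring, the same atoms joined differently. For the measured compounds named here, no measured step covers this exchange, and the limit of > 30000 nM in this assay, at which 2 of the 3 values shown sit, weighs on any expectation. Compound 4 is therefore expected to stay near that limit, with a step of about an at least 1.2-fold lower number from compound 3 to compound 4 (0.07 log units; that floor lies within the scatter). The estimate for compound 4 is 25000 nM, between 6000 nM and 60000 nM.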

Compound 4, concentration for 50% growth inhibition: 3400 nM
Beside the measured number, compound 4's estimate is 7.4-fold (0.87 log units) above it; the measured number lies below the stated range.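

In this assay, the same atoms joined differently are enough to change the result at this place: cyclopentylmethyl in place of cyclohexyl gives an at least 8.8-fold lower number from compound 3 to compound 4 (0.94 log units; beyond the scatter). The exchange for 2-methylprop-1-en-1-yl gives an at least 8.8-fold lower number from compound 2 to compound 4 (0.94 log units; beyond the scatter), while cyclopentyl in place of isobutyl gives a 1.1-fold lower number from compound 1 to compound 4 (0.03 log units; within the scatter), so a ring on this chain can match the open-chain isopentyl group. The first two steps are floors only, and the values of compound 2 and compound 3 are limits of the assay: the limit of > 30000 nM in this assay, at which 2 of the 4 values shown sit.

As far as these compounds go, whether a longer chain such as 3-cyclopentylpropyl, or an amine on the chain end, would keep this growth inhibition stays open.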